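Expected Solubility After One Small Substitution

This account rests on a few compounds, and the source may have more. Where it says the series, first, only, none or still open, it means among the compounds named here.

Only limited data are available in a physicochemical assay for solubility, at pH 7.4; on this read-out lower numbers stand for lower solubility and higher numbers for higher solubility. Compound 1 `C[C@H]1[C@H](N)CN1c1cc2c(cc1F)c(=O)c(C(=O)O)cn2C1CC1` gives 9.9 ug/mL, and a further entry for compound 1 carries no single number. Compound 2 `CC1(N)CN(c2c(F)cc3c(=O)c(C(=O)O)cn(C4CC4)c3c2F)C1` gives 0.8 ug/mL; 15.3 ug/mL (2 entries). For the measured compounds named here, the one number for compound 1 therefore falls inside the wide span of the several entries of compound 2 in this assay, 0.8 ug/mL; 15.3 ug/mL (2 entries), and compound 1 has no clear rank on these numbers.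

Compound 3 `C[C@@H]1[C@@H](N(C)C)CN1c1cc2c(cc1F)c(=O)c(C(=O)O)cn2C1CC1` has not yet been measured. It differs from compound 1 in the group on an aromatic carbon of a six-membered aromatic ring of carbon only, ortho to a fluoro group: a group of 8 heavy atoms (6 carbon, 2 nitrogen; one four-membered non-aromatic ring with 1 hetero atom) in place of a group of 6 heavy atoms (4 carbon, 2 nitrogen; one four-membered non-aromatic ring with 1 hetero atom), on an aromatic carbon. Both the leaving and the entering group hold one four-membered non-aromatic ring with 1 hetero atom.

Going by the values given here, no measured pair shows the size of such a change. With compound 2 at 0.8 ug/mL; 15.3 ug/mL (2 entries) as a reminder of how far entries for one compound can lie apart, no step beyond the scatter is expected in this assay, in either direction. The expected change is a 1.0-fold higher number from compound 1 to compound 3 (0.00 log units; within the scatter). The estimate for compound 3 is 10 ug/mL, with an expected range from 3 ug/mL to 35 ug/mL.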

Compound 3, solubility: 96.3 ug/mL
Estimate against measurement, compound 3: 9.6-fold (0.98 log units) below; the whole stated range lies below it.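

In this assay, the group on an aromatic carbon ortho to a fluoro group proves able to move the read-out, with a replacement that keeps the four-membered non-aromatic ring giving a 9.7-fold higher number from compound 1 to compound 3 (0.99 log units; beyond the scatter). Compound 1 and compound 2 formed no pair that differed in one place, so this is the only step shown that gives a size for a change here, and it lies beyond the scatter. It still rests on a single pair, and entries for one compound can lie far apart, so its size should be read with caution given: the several entries of compound 2 in this assay, 0.8 ug/mL; 15.3 ug/mL (2 entries)

As far as these compounds go, what remains open is which part of the change goes with the step, since the entering group has 6 carbon against 4 carbon, 0 hydrogen-bond donors against 1 hydrogen-bond donor, and 2 defined stereocentres drawn with the opposite configuration to those of the leaving group. A methylamino group on the same four-membered ring, together with a comparison of the two configurations carrying the same amine, would help separate these contributions in this assay.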